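A Methoxy Group Added to Two Related Cores

The source may hold more compounds than are shown below. What is called first, only, known or untested is meant among the compounds shown, and "the series" means these compounds.

compound 1, `O=C1C=COC(/C=C/c2ccccc2)C1`: 127 uM
compound 2, `COc1ccc(/C=C/C2CC(=O)C=CO2)cc1`: 145 uM
compound 3, `COc1ccc(/C=C/C2CC=CC(=O)N2)cc1OC`: > 964 uM, which is a limit of the assay and not a number

All three were tested in an ADME assay on HaCaT cells (Homo sapiens) for inhibition, read by sulforhodamine B assay, with a stated time of 48 h; on this read-out lower numbers stand for stronger inhibition of growth and higher numbers for weaker inhibition of growth. Compound 1 and compound 2 share a core and differ by one change, (methoxy in place of hydrogen on an aromatic carbon), which gave a 1.1-fold higher number from compound 1 to compound 2 (0.06 log units; within the scatter). For compound 3 only a limit is known: the limit of > 964 uM in this assay, at which 1 of the 3 values shown sits. How the core of compound 3 differs from the core of compound 1 is not broken down here.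

Compound 4, `COc1cc(OC)c(OC)cc1/C=C/C1CC=CC(=O)N1`, has not yet been measured. It differs from compound 3 by methoxy in place of hydrogen on an aromatic carbon. This is the same kind of change as that from compound 1 to compound 2, though the surroundings differ: in compound 4 the entering methoxy sits ortho to a group of 9 heavy atoms, meta to a methoxy group and para to a methoxy group, while in compound 2 it sits para to a group of 9 heavy atoms.

Because the earlier step was a 1.1-fold higher number from compound 1 to compound 2 (0.06 log units; within the scatter), the step expected for compound 4 is a number no higher from compound 3 to compound 4 (the limit leaves the size open). Compound 4 is therefore expected to give 964 uM, within a range from 480 uM to 2000 uM, and quite possibly only a limit again.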

Compound 4, concentration for growth inhibition (reported as GI): > 864 uM
Compound 4 was reported as a limit; the forecaster's own chance of this, stated with the estimate: 75%; the middle value lies beyond the limit too.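

Compound 3 and compound 4 are both reported only as limits and not as numbers, so the step between them cannot be read. The limit for compound 3 is this: the limit of > 964 uM in this assay, at which 1 of the 4 values shown sits. The limit for compound 4 is this: the limit of > 864 uM in this assay, at which 1 of the 4 values shown sits. The compounds shown leave open how strongly either compound inhibits growth in this assay and whether the added methoxy changes that on this core.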